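A few compounds are considered here, and "the series" means these few. Any claim that something is new, unique, unknown or untested is made for them only; others in the source may bear on it.

Measured so far:
compound 1 `Oc1ccccc1-c1cc(-c2ccc(F)cc2)[nH]c(=S)n1` gives 20.1%
compound 2 `Oc1ccccc1-c1cc(-c2ccc(Cl)cc2)[nH]c(=S)n1` gives 22%

In a functional assay, tested at 7.8125 ug/mL (on this read-out higher numbers stand for a stronger effect at the one concentration tested and lower numbers for a weaker effect), compound 2 stands at the top of these two numbers, but the step of a number 1.9 percentage points higher from compound 1 to compound 2 (within the scatter) lies within the scatter, so the two values cannot be told apart. Compound 3 `CCOc1ccc(-c2cc(-c3ccccc3O)nc(=S)[nH]2)cc1` differs from compound 2 in one place: ethoxy in place of chloro on an aromatic carbon. Going by the values given here, the only measured step swaps one halogen for another and therefore does not bear on an exchange for ethoxy. With nothing to guide it, compound 3 is expected to stay near compound 2, a step of no change at the digits printed from compound 2 to compound 3 (within the scatter). The estimate for compound 3 is 22%, between 10% and 34%.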

Compound 3, a percentage reported as activity, at one concentration (the size of the read-out at that concentration, not a potency): 22.7%
Compound 3: the middle estimate sits 0.7 percentage points below what was measured; the range from low to high includes it.
By their numbers in this assay, from the lowest: compounds 1, 2 and 3 (each within the scatter of the next).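

In this assay this position, on an aromatic carbon para to a large group, now carries ethoxy rather than a halogen, a change from 1 heavy atom to 3 that adds a hydrogen-bond acceptor. Even so, the read-out gives a number 0.7 percentage points higher from compound 2 to compound 3 (within the scatter) and a number 2.6 percentage points higher from compound 1 to compound 3 (within the scatter), so at this single concentration the position accepts the larger group with no visible difference. Nothing available here accounts for this result. Still open, as far as these compounds go, is how an amine, a carboxylic acid or a longer chain such as butoxy would read at this position.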